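Methyl walk on an aryloxyacetanilide series, chromatographic lipophilicity

A few compounds are considered here, and "the series" means these few. Any claim that something is new, unique, unknown or untested is made for them only; others in the source may bear on it.

Measured so far, in a physicochemical assay for lipophilicity, read by HPLC, in phosphate buffer, measured as chromatographic lipophilicity, at pH 7.4; on this read-out lower numbers stand for lower lipophilicity and higher numbers for higher lipophilicity:
compound 1 `Cc1cc(C)cc(NC(=O)COc2cc(C)nc3ccccc23)c1` gives 5.39
compound 2 `Cc1cc(C)cc(NC(=O)COc2cc(C)nc3ccc(C)cc23)c1` gives 5.95
compound 3 `COc1ccc2nc(C)cc(OCC(=O)Nc3cccc(C)c3)c2c1` gives 4.83

Compound 1 and compound 2 differ in one place, (methyl in place of hydrogen on an aromatic carbon), and the step was a number 0.56 log units higher from compound 1 to compound 2 (beyond the scatter). Compound 3 sits lowest of the three; how its core differs from that of compound 1 is not broken down here.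

Compound 4 `COc1ccc2nc(C)cc(OCC(=O)Nc3cc(C)ccc3C)c2c1` awaits measurement in this assay. It differs from compound 3 by methyl in place of hydrogen on an aromatic carbon. This is the same kind of change as that from compound 1 to compound 2, not the same: in the earlier pair the methyl enters on a ring that is part of a fused system of two rings, meta and para to a fused ring, whereas here it enters on a six-membered ring of carbon only, ortho to a large group and para to a methyl group.

Within the data shown here, for compound 4 the expected step is a number 0.52 log units higher from compound 3 to compound 4 (beyond the scatter), resting on the step of a number 0.56 log units higher from compound 1 to compound 2 (beyond the scatter) as the only methyl-for-hydrogen step measured. Compound 4 is thus estimated at 5.35, expected between 5 and 5.7.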

Compound 4, distribution coefficient: 5.05
Compound 4: middle estimate off by 0.30 log units, on the high side, within the range that was stated.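

In this assay methyl in place of hydrogen on an aromatic carbon gave a number 0.22 log units higher from compound 3 to compound 4 (within the scatter) and, on the core of compound 1, gave a number 0.56 log units higher from compound 1 to compound 2 (beyond the scatter) as the earlier step of the same kind. The size of the step therefore did not carry over unchanged from one pair to the other, although two pairs are too few to set a rule for the series, and they differ both in the core and in the ring that takes the methyl, so the data cannot separate these two differences. Nothing available bears on why the two steps differ.

Still open, as far as these compounds go, is the step for a methyl entering the six-membered aromatic ring of carbon only on the core of compound 1, ortho to a large group, which would separate the core from the place. From the compounds shown here alone, how an ethyl group or a carboxylic acid at that same place on compound 3 would read in this assay also remains open.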